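A few compounds are considered here, and "the series" means these few. Any claim that something is new, unique, unknown or untested is made for them only; others in the source may bear on it.

Compound 1 `CN1C/C(=C\c2cccnc2)C(=O)/C(=C/c2ccccc2F)C1` gives 5420 nM in a functional assay on SMMC-7721 cells (Homo sapiens) for cytotoxicity, read by MTT assay, with a stated time of 24 h; on this read-out lower numbers stand for stronger inhibition and higher numbers for weaker inhibition.
Compound 2 `CN1C/C(=C\c2cccnc2)C(=O)/C(=C/c2ccccc2C(F)(F)F)C1` gives 3900 nM.
Compound 3 `CN1C/C(=C\c2ccc(C#N)cc2)C(=O)/C(=C/c2cccnc2)C1` gives 13600 nM.

Among these three numbers compound 1 stands second highest. Its nearest neighbour is compound 2, with a 1.4-fold lower number from compound 1 to compound 2 (0.14 log units; within the scatter); furthest away is compound 3, with a 2.5-fold higher number from compound 1 to compound 3 (0.40 log units; beyond the scatter). Compound 4 `Cc1ccc(S(=O)(=O)N2C/C(=C\c3cccnc3)C(=O)/C(=C/c3ccccc3F)C2)cc1` differs from compound 1 by (4-methylphenyl)sulfonyl in place of methyl on an amine nitrogen in a ring. Among the measured compounds shown here, neither measured step touches the amine nitrogen in a ring: both alter the aromatic groups on the chain carbons, so no step bears directly on this change, and no size of step beyond the scatter is expected in this assay, in either direction, though with little certainty. Compound 4 is therefore estimated at 4500 nM, within 1500 nM to 13000 nM, which would mean a 1.2-fold lower number from compound 1 to compound 4 (0.08 log units; within the scatter).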

Compound 4, half-maximal inhibitory concentration: 10300 nM
The estimate for compound 4 lay 2.3-fold (0.36 log units) below the measured number; low and high end bracket the measured number.
By their numbers in this assay, from the lowest: compounds 2, 1, 4 and 3 (each within the scatter of the next, the first and the last beyond it).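

In this assay, putting (4-methylphenyl)sulfonyl in place of methyl on the amine nitrogen in a ring gives a 1.9-fold higher number from compound 1 to compound 4 (0.28 log units; within the scatter) and so leaves the two compounds indistinguishable. Among the compounds shown here, this is the first look at that nitrogen, and it shows that a group with an aromatic ring and a sulfonyl can sit there without a difference beyond the scatter. Nothing available explains this result. On these data alone, what a benzyl, an acetyl or a plain hydrogen on that nitrogen would give remains open. So does whether this exchange reads the same with the aromatic groups of compound 2 or compound 3.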